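Positional shift of chlorine on the aryl group

A few compounds are considered here, and "the series" means these few. Any claim that something is new, unique, unknown or untested is made for them only; others in the source may bear on it.

Compound 1 `Cn1c(-c2cccc(Cl)c2)nc2c(NC3CCCC3)ncnc21`: 2530 nM
Compound 2 `CCn1c(-c2ccccc2)nc2c(NC3CCOC3)ncnc21`: 11500 nM
Compound 3 `Cn1c(-c2ccccc2)nc2c(NC3CCC3)ncnc21`: 3730 nM

In a functional assay on CHO cells for antagonist activity at adenosine receptor A2b (Homo sapiens), read by 33P incorporation, with a stated time of 20 min (on this read-out higher numbers stand for weaker inhibition and lower numbers for stronger inhibition), compound 1 gives the lowest number of the three. Compound 3 sits within the scatter of compound 1; compound 2 gives a number beyond the scatter above it. Compound 4 `Cn1c(-c2ccc(Cl)cc2)nc2c(NC3CCCC3)ncnc21` keeps the shared core of compound 1 and the cyclopentylamino group and differs only in 4-chlorophenyl in place of 3-chlorophenyl on an aromatic carbon. No measured pair shows the effect of moving the chlorine on this aryl group, so the size of the step is not anchored by any shown pair. The step of a 1.2-fold higher number from compound 1 to compound 4 (0.07 log units; within the scatter) is expected to stay within the scatter, with no clear direction. Compound 4 is therefore estimated at 3000 nM, with a range from 800 nM to 12000 nM.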

Compound 4, inhibition constant: > 30000 nM
Compound 4: a limit, no number; the forecaster's own chance of this, stated with the estimate: 5%; middle value at least 10-fold (1.00 log units) from the limit.
By their numbers in this assay, from the lowest: compounds 1 and 3 (each within the scatter of the next); then compound 2. At a limit, above all of these: compound 4.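

In this assay, for the compounds shown here, moving the chlorine around the aryl group gives an at least 11-fold higher number from compound 1 to compound 4 (1.07 log units; beyond the scatter), so at this aromatic carbon the placement of the chlorine matters, which no earlier pair could show. Compound 4 stands as a limit and not a number: the limit of > 30000 nM in this assay, at which 1 of the 4 values shown sits. The 3-chlorophenyl and 4-chlorophenyl groups match in every counted feature, so the chlorine's placement alone separates them.

Open, as far as these compounds go, is whether a fluorine or a methoxy group in place of this chlorine on the 4-chlorophenyl group would read the same way. Also open, from the compounds shown here alone, is how an unsubstituted phenyl group behaves alongside the cyclopentylamino group.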